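Methyl to trifluoromethyl on the pendant phenyl ring

The compounds below may be only part of what the source reports. "The series", "measured", "known", "first", "only" and "open" are said of these compounds alone.

Of the compounds shown here, three sharing one core have been measured in a functional assay on U-87MG ATCC cells (Homo sapiens) for inhibition, read by MTT assay, with a stated time of 72 h; a higher number here means a weaker inhibitor, a lower number a stronger inhibitor. Compound 1 `COc1cc2c(Oc3ccc(NC(=O)c4nn(-c5ccccc5)c(=O)cc4C)cc3F)ccnc2cc1OCCCN1CCCC1` gives 1100 nM. Compound 2 `COc1cc2c(Oc3ccc(NC(=O)c4nn(-c5ccccc5C)c(=O)cc4C)cc3F)ccnc2cc1OCCCN1CCCC1` gives 2960 nM, and compound 3 `COc1cc2c(Oc3ccc(NC(=O)c4nn(-c5ccccc5C)c(=O)cc4C)cc3F)ccnc2cc1OCCCN1CCN(C)CC1` gives 3720 nM. Among these three numbers compound 2 holds the second highest; its step to compound 3 lies within the scatter, while the step from compound 1 to compound 2, a 2.7-fold higher number from compound 1 to compound 2 (0.43 log units; beyond the scatter), lies beyond it. The step from compound 2 to compound 3, a 1.3-fold higher number from compound 2 to compound 3 (0.10 log units; within the scatter), shows that the change at the far end of the chain hardly matters here.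

Compound 4 `COc1cc2c(Oc3ccc(NC(=O)c4nn(-c5ccccc5C(F)(F)F)c(=O)cc4C)cc3F)ccnc2cc1OCCCN1CCCC1` differs from compound 2 in one place: trifluoromethyl in place of methyl on an aromatic carbon. Among the compounds with values here, the only measured step that bears on this position is a 2.7-fold higher number from compound 1 to compound 2 (0.43 log units; beyond the scatter), a modest weakening when methyl replaced hydrogen. A further change at the same carbon is therefore expected to leave the number unchanged or to raise it modestly, not to lower it. For compound 4 the expected step is a 1.7-fold higher number from compound 2 to compound 4 (0.23 log units; within the scatter), giving an estimate of 5000 nM with a range from 2000 nM to 12000 nM in this assay.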

Compound 4, half-maximal inhibitory concentration: 1010 nM
Compound 4: the middle estimate sits 5.0-fold (0.69 log units) above what was measured, and the stated range ends above it.
By their numbers in this assay, from the lowest: compounds 4 and 1 (each within the scatter of the next); then compounds 2 and 3 (each within the scatter of the next).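

The earlier compounds shown here showed only a weakening at this carbon, but in this assay the change to trifluoromethyl gives a 2.9-fold lower number from compound 2 to compound 4 (0.47 log units; beyond the scatter) and so runs opposite to the step from hydrogen to methyl. Against the unsubstituted phenyl of compound 1, the same group gives a 1.1-fold lower number from compound 1 to compound 4 (0.04 log units; within the scatter) and leaves the two compounds within the scatter of each other, so of the two substituents shown at this carbon, only methyl moves the number beyond the scatter from hydrogen. Nothing at hand explains why methyl and trifluoromethyl part ways here.

From the compounds shown here alone, it remains open whether a chlorine atom or a methoxy group on this carbon would follow methyl or trifluoromethyl. Also open, going by these compounds, is whether the step from 2-methylphenyl to 2-(trifluoromethyl)phenyl would hold with the 4-methylpiperazin-1-yl chain of compound 3 in place of the pyrrolidin-1-yl.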